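Dropping a Fluorine from Two Different Cores

A few compounds are considered here, and "the series" means these few. Any claim that something is new, unique, unknown or untested is made for them only; others in the source may bear on it.

In a functional assay on MDA-MB-231 cells (Homo sapiens) for cytotoxicity, read by MTT assay, with a stated time of 72 h (a lower number here means a stronger inhibitor, a higher number a weaker inhibitor), compound 3 `O=C(Nc1ccc(Oc2ccncc2-c2cccnc2)c(F)c1)c1nn(-c2cccc(F)c2)c(=O)c2ccccc12` gives 72 nM, the lowest number among the three measured compounds. Compound 1 `Fc1ccc(Nc2cc(Nc3ccc(Oc4ccncc4-c4cccnc4)c(F)c3)ncn2)cc1F` gives 6770 nM, and compound 2 `Fc1ccc(Nc2cc(Nc3ccc(Oc4ccncc4-c4cccnc4)c(F)c3)ncn2)cc1` gives 14100 nM. The difference between the core of compound 3 and the core of compound 1 is not broken down here. Compound 4 `O=C(Nc1ccc(Oc2ccncc2-c2cccnc2)c(F)c1)c1nn(-c2ccccc2)c(=O)c2ccccc12` has not yet been measured; it differs from compound 3 by hydrogen in place of fluoro on an aromatic carbon. The same kind of change, (hydrogen in place of fluoro on an aromatic carbon), separates compound 1 from compound 2, except that in that pair the changed carbon also sits ortho to a fluoro group, and there it gave a 2.1-fold higher number from compound 1 to compound 2 (0.32 log units; beyond the scatter). Within the data shown here, because a 2.1-fold higher number from compound 1 to compound 2 (0.32 log units; beyond the scatter) is the only earlier step of this kind and the surroundings of the changed carbon are not identical, the expected step is a 1.8-fold higher number from compound 3 to compound 4 (0.26 log units; within the scatter), a small loss. Compound 4 is therefore estimated at 130 nM, with a likely range from 50 nM to 320 nM.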

Compound 4, half-maximal inhibitory concentration: 8200 nM
The estimate for compound 4 lay 63-fold (1.80 log units) below the measured number, and the stated range ends below it.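

Swapping 3-fluorophenyl for phenyl gives a large step in this assay, a 110-fold higher number from compound 3 to compound 4 (2.06 log units; beyond the scatter). The same swap therefore does not carry its size from one core to the other, as the two steps show when set side by side: the same change on two cores in this assay, a 2.1-fold higher number (0.32 log units; beyond the scatter) from compound 1 to compound 2 and a 110-fold higher number (2.06 log units; beyond the scatter) from compound 3 to compound 4, 55-fold (1.74 log units) apart, beyond the scatter of two such steps

The number rises on both cores, so the direction is shared, but two pairs are too few to make a rule of that, and they do not show why the sizes differ, since the core and the surroundings of the changed carbon both vary between the pairs.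

Open, from the compounds shown here alone, is whether a chloro group, a methoxy group or an amine at that same place on the ring would keep a number close to that of compound 3 or give one closer to that of compound 4. Also open, going by these compounds, is how large this swap would be on a third core.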